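Methyl for fluoro on the pyridine of compound 2

This account rests on a few compounds, and the source may have more. Where it says the series, first, only, none or still open, it means among the compounds named here.

Of the compounds shown here, three sharing a common core have been measured in an assay for inhibition of kynurenine 3-monooxygenase (Homo sapiens), read by mass spectrometry, with a stated time of 1 h; a lower number here means a stronger inhibitor, a higher number a weaker inhibitor. Compound 1 `C[C@@H](Oc1cc2oc(=O)n(CCC(=O)O)c2cc1Cl)c1ccc(Cl)cn1` gives 3.16 nM. Compound 2 `C[C@@H](Oc1cc2oc(=O)n(CCC(=O)O)c2cc1Cl)c1ccc(F)cn1` gives 2.51 nM, the second highest of the three numbers, and compound 3 `Cc1ccc([C@@H](C)Oc2cc3onc(CCC(=O)O)c3cc2Cl)nn1` gives 2 nM; the three values all lie within the scatter of one another. For the measured compounds named here, the only single-point step so far, a 1.3-fold lower number from compound 1 to compound 2 (0.10 log units; within the scatter), shows that swapping one halogen for another at this position leaves the read-out essentially unchanged.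

Compound 4 `Cc1ccc([C@@H](C)Oc2cc3oc(=O)n(CCC(=O)O)c3cc2Cl)nc1` is not yet measured. It differs from compound 2 by methyl in place of fluoro on an aromatic carbon. Going by the values given here, the step from compound 1 to compound 2 is the one comparison that bears on this change, since it probes the same position, and it was within the scatter. Compound 3 carries a methyl on a different ring system and is not a one-place comparison. Compound 4 is therefore expected to sit close to compound 2, with a 1.0-fold lower number from compound 2 to compound 4 (0.00 log units; within the scatter) expected to be a step within the scatter. The estimate for compound 4 is 2.5 nM, between 1.2 nM and 5.5 nM.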

Compound 4, half-maximal inhibitory concentration: 3.16 nM
The estimate for compound 4 lay 1.3-fold (0.10 log units) below the measured number; low and high end bracket the measured number.
By their numbers in this assay, from the lowest: compounds 3, 2, 1 and 4 (each within the scatter of the next).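

In this assay, the earlier comparison covered only an exchange of one halogen for another, and this result extends it to a carbon group on the same aromatic carbon, para to a large group. Methyl in place of a halogen gives a 1.3-fold higher number from compound 2 to compound 4 (0.10 log units; within the scatter) and no change at the digits printed from compound 1 to compound 4 (within the scatter), so neither step leaves the scatter and fluoro, chloro and methyl are not told apart at this position in these compounds. Nothing measured here accounts for why these three groups read alike.

As far as these compounds go, whether an amine, a methoxy group or a longer chain at this position would also stay within the scatter remains open. Also open, from the compounds shown here alone, is whether methyl in place of a halogen would read the same way on the core of compound 3.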